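Sulfur side chains: from carbamoyl to methylsulfanyl

The compounds below may be only part of what the source reports. "The series", "measured", "known", "first", "only" and "open" are said of these compounds alone.

Values in a functional assay on HT cells (Homo sapiens) for antiproliferative activity, read by fluorescence, with a stated time of 72 h; a higher number here means a weaker inhibitor of growth, a lower number a stronger inhibitor of growth:
- compound 1 `CC(C)c1n[nH]c2c(NCc3ccc(-c4ccccn4)cc3)nc(SC(CO)C(C)C)nc12`: 980 nM
- compound 2 `CC(C)c1n[nH]c2c(NCc3ccc(-c4ccccn4)cc3)nc(SCCCN(C)C)nc12`: 105 nM
- compound 3 `CC(C)c1n[nH]c2c(NCc3ccc(-c4ccccn4)cc3)nc(SCCC(N)=O)nc12`: 120 nM

Compound 3 sits at 120 nM and cannot be separated from compound 2 at 105 nM, as shown by a 1.1-fold higher number from compound 2 to compound 3 (0.06 log units; within the scatter). Compound 1 stands apart, with an 8.2-fold lower number from compound 1 to compound 3 (0.91 log units; beyond the scatter) and a 9.3-fold lower number from compound 1 to compound 2 (0.97 log units; beyond the scatter).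

Compound 4 `CSCCSc1nc(NCc2ccc(-c3ccccn3)cc2)c2[nH]nc(C(C)C)c2n1` keeps the shared core and differs only in the sulfur chain, where 2-carbamoylethyl becomes 2-(methylsulfanyl)ethyl: methylsulfanyl in place of carbamoyl on a saturated chain carbon, two bonds along the chain from a sulfur. This is methylsulfanyl in place of carbamoyl on a saturated chain carbon, two bonds along the chain from a sulfur.

Among the compounds with values here, no measured step makes this exact exchange. Within the data shown here, the closest precedent is the exchange at the same place between compound 2 and compound 3, carbamoyl in place of (dimethylamino)methyl, which gave a 1.1-fold higher number from compound 2 to compound 3 (0.06 log units; within the scatter). The two larger steps from compound 1 replace the whole 1-(hydroxymethyl)-2-methylpropyl group and bear on this change less directly. Among the measured compounds shown here, no measured compound carries methylsulfanyl, so the range is kept wide. In this assay, the expected result is a 1.2-fold higher number from compound 3 to compound 4 (0.07 log units; within the scatter), with no shift beyond the scatter anticipated. For compound 4 the estimated value is 140 nM, with an expected range of 60 nM to 350 nM.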

Compound 4, concentration for 50% growth inhibition: 975 nM
The estimate for compound 4 lay 7.0-fold (0.84 log units) below the measured number, and the stated range ends below it.
By their numbers in this assay, from the lowest: compounds 2 and 3 (each within the scatter of the next); then compounds 4 and 1 (each within the scatter of the next).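

In this assay, within the data shown here, the end of the sulfur chain matters after all: methylsulfanyl in place of carbamoyl gives an 8.1-fold higher number from compound 3 to compound 4 (0.91 log units; beyond the scatter) and methylsulfanyl in place of (dimethylamino)methyl gives a 9.3-fold higher number from compound 2 to compound 4 (0.97 log units; beyond the scatter), whereas the only earlier exchange at this place stayed within the scatter. Replacing 1-(hydroxymethyl)-2-methylpropyl on the sulfur is therefore not enough by itself to lower the number, since 2-(methylsulfanyl)ethyl gives a 1.0-fold lower number from compound 1 to compound 4 (0.00 log units; within the scatter), unlike the two nitrogen-bearing chains. Among these four compounds, the chains with a nitrogen, in compound 2 and compound 3, give the lower numbers and those without one, in compound 1 and compound 4, give the higher numbers, with no compound against this pattern, but no measurement here accounts for it.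

Four chains are too few to tell whether the nitrogen itself is what counts, and a primary amine, a carboxylic acid or a simple hydroxyl at the chain end would test that reading. A longer chain ending in methylsulfanyl would show whether the chain end or its distance from the sulfur carries the difference.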